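Swapping an Acetamido for a Methyl(methylsulfonyl)amino Group

The source may report more compounds than this note shows. Statements on the series, on what has been measured and on what is new or still open speak of the compounds shown alone.

Compound 1 `CC(=O)Nc1cccc2c1CCCC2c1c[nH]cn1` carries an acetamido group on a fused two-ring core. In an assay on isolated protein for binding affinity to Alpha-2B adrenergic receptor (Rattus norvegicus), read by radioligand binding (on this read-out lower numbers stand for stronger inhibition and higher numbers for weaker inhibition), compound 1 gives 3020 nM, the highest of the three numbers recorded so far, which here means the weakest binding. Compound 3 `CCS(=O)(=O)Nc1cccc(Cc2c[nH]cn2)c1`, built on a different core, gives 977 nM in this assay, a lower number than compound 1 and beyond the usual scatter. Compound 2 `CS(=O)(=O)Nc1c(O)ccc2c1CCCC2c1c[nH]cn1` keeps the core of compound 1 but carries a methylsulfonylamino group together with a hydroxyl; in this assay compound 2 gives 47.9 nM, far lower than the number of compound 1.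

Compound 4 `CN(c1cccc2c1CCCC2c1c[nH]cn1)S(C)(=O)=O` has not yet been measured. It differs from compound 1 in one place: methyl(methylsulfonyl)amino in place of acetamido on an aromatic carbon. Going by the values given here, no pair of measured compounds shows this exact step, so the expectation rests only on the three values. Compound 2 with 47.9 nM suggests that a sulfonyl-bearing amino group on this core can go with a much lower number, yet compound 2 also carries a hydroxyl and its nitrogen is not methylated. The step is therefore expected to be modest, a 2.0-fold lower number from compound 1 to compound 4 (0.30 log units; within the scatter). Compound 4 is estimated at 1500 nM, likely between 300 nM and 7000 nM.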

Compound 4, inhibition constant: 912 nM
For compound 4 the middle estimate is 1.6-fold (0.22 log units) above the measured one; measured number inside the range.
By their numbers in this assay, from the lowest: compound 2; then compounds 4 and 3 (each within the scatter of the next); then compound 1.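

On this aromatic carbon, methyl(methylsulfonyl)amino in place of acetamido gives a 3.3-fold lower number from compound 1 to compound 4 (0.52 log units; beyond the scatter) in this assay, so the number falls, which here means stronger binding, even though the entering group is the larger one, with 6 heavy atoms against 4. The entering group has 0 hydrogen-bond donors, so the hydrogen-bond donor of acetamido is not required for binding at this level on the shared core. Nothing measured here gives a reason for this step.

Which part of the new group matters stays open: the methyl on the nitrogen and the sulfonyl enter together in this one change. Also open, as far as these compounds go, is how a plain amine, a carboxylic acid or a longer chain on the sulfonyl would fare on this same aromatic carbon.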